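The source may hold more compounds than are shown below. What is called first, only, known or untested is meant among the compounds shown, and "the series" means these compounds.

Three compounds share one core and differ only in a group carried on it. Compound 1 `O=[N+]([O-])c1ccc(CN2CCC(n3cc(CC(OCc4cc(-c5cccc(F)c5)no4)c4ccc(Br)cc4)nn3)CC2)cc1` gives in a functional assay on MCF7 cells (Homo sapiens) for cytotoxicity, with a stated time of 48 h (a lower number here means a stronger inhibitor, a higher number a weaker inhibitor), a value of 8000 nM. Compound 2 `COc1cccc(-c2cc(COC(Cc3cn(C4CCN(Cc5ccc([N+](=O)[O-])cc5)CC4)nn3)c3ccc(Br)cc3)on2)c1` gives 7000 nM in this assay, and compound 3 `O=[N+]([O-])c1ccc(CN2CCC(n3cc(CC(OCc4cc(-c5ccccc5F)no4)c4ccc(Br)cc4)nn3)CC2)cc1` gives 8000 nM in this assay. From compound 1 to compound 2 the change is methoxy in place of fluoro on an aromatic carbon, and the step was a 1.1-fold lower number from compound 1 to compound 2 (0.06 log units; within the scatter). Compound 3 rests on a different core from compound 1: 2-fluorophenyl in place of 3-fluorophenyl on an aromatic carbon, with a step of no change at the digits printed from compound 1 to compound 3 (within the scatter).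

Compound 4 `COc1ccccc1-c1cc(COC(Cc2cn(C3CCN(Cc4ccc([N+](=O)[O-])cc4)CC3)nn2)c2ccc(Br)cc2)on1` has not been measured. It differs from compound 3 by methoxy in place of fluoro on an aromatic carbon. This is the same kind of change as that from compound 1 to compound 2, though the place is not identical: in the earlier pair the exchange sits meta to a large group, here ortho to a large group. Compound 1 gives 8000 nM and compound 2 gives 7000 nM, so the same kind of exchange is expected to move the number little. The expected step is a 1.1-fold lower number from compound 3 to compound 4 (0.03 log units; within the scatter), set beside the measured 1.1-fold lower number from compound 1 to compound 2 (0.06 log units; within the scatter). Compound 4 is therefore estimated at 7500 nM in this assay, between 3500 nM and 16000 nM.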

Compound 4, half-maximal inhibitory concentration: 3000 nM
Estimate against measurement, compound 4: 2.5-fold (0.40 log units) above, and the stated range ends above it.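

In this assay compound 4 is the only one of the four set apart from the others, with a 2.7-fold lower number from compound 3 to compound 4 (0.43 log units; beyond the scatter) and a 2.3-fold lower number from compound 2 to compound 4 (0.37 log units; beyond the scatter) and a 2.7-fold lower number from compound 1 to compound 4 (0.43 log units; beyond the scatter) all printed as beyond the scatter. Set against the earlier step for methoxy in place of fluoro, the new step cannot be told apart from it: the same change on two cores in this assay, a 1.1-fold lower number (0.06 log units; within the scatter) from compound 1 to compound 2 and a 2.7-fold lower number (0.43 log units; beyond the scatter) from compound 3 to compound 4, 2.3-fold (0.37 log units) apart, within the scatter of two such steps. For the compounds shown here, the two pairs therefore show no firm difference in how this change carries from one core to the other, yet with only one pair on each core they do not show that it carries over equally either.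

The compounds shown leave open whether other groups in the same place on the phenyl ring, such as hydroxyl, an amine or a longer alkoxy chain, would give numbers like that of compound 4. They also leave open whether 2-methoxyphenyl would keep its lower number if the bromo group gave way to chloro or an amine.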